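Dropping the Tetrahydroxyoxanyl Group: Expected Cytotoxicity Read-out

This account rests on a few compounds, and the source may have more. Where it says the series, first, only, none or still open, it means among the compounds named here.

Compound 1, `COc1cc2c(cc1O)CCC(C)(CC(=O)O)O2`: 100%
Compound 2, `COc1cc2c(cc1O)CCC(C)(CCNC(=O)C[C@H]1OC(O)[C@H](O)[C@@H](O)[C@@H]1O)O2`: 88.1%

In an ADME assay on SH-SY5Y cells (Homo sapiens) for cytotoxicity, read by MTT assay, with a stated time of 24 h, tested at 3.1 uM (on this read-out higher numbers stand for a weaker effect at the one concentration tested and lower numbers for a stronger effect), compound 1 gives 100%, and compound 2 gives 88.1%. Compound 2 has the lower of the two numbers, and its gap to compound 1 lies beyond the scatter, so compound 2 shows the stronger effect here. Compound 3, `COc1cc2c(cc1O)CCC(C)(CCNC(C)=O)O2`, is not yet measured. It differs from compound 2 by hydrogen in place of 3,4,5,6-tetrahydroxyoxan-2-yl on a saturated chain carbon bound to a carbonyl carbon. Among the compounds with values here, no step between measured compounds is known, and the two values lie close together, so only a small rise in this assay is expected, a number 6.9 percentage points higher from compound 2 to compound 3 (within the scatter), within the scatter. Compound 3 is therefore estimated at 95%, ranging from 80% to 105%.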

Compound 3, a percentage reported as activity, at one concentration (the size of the read-out at that concentration, not a potency): 90.7%
Compound 3: the middle estimate sits 4.3 percentage points above what was measured; low and high end bracket the measured number.
By their numbers in this assay, from the lowest: compounds 2, 3 and 1 (each within the scatter of the next, the first and the last beyond it).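

In this assay, within the data shown here, hydrogen in place of 3,4,5,6-tetrahydroxyoxan-2-yl on a saturated chain carbon bound to a carbonyl carbon gives a number 2.6 percentage points higher from compound 2 to compound 3 (within the scatter) and so shows that losing this group of 10 heavy atoms leaves no step that can be told from scatter. Acetamidomethyl in place of carboxy on a saturated chain carbon bound to a saturated ring carbon gives a number 9.3 percentage points lower from compound 1 to compound 3 (within the scatter) and is likewise no clear change. Nothing at hand explains either step. As far as these compounds go, whether an amine or a longer chain on the carbon bound to the carbonyl carbon would move the read-out remains open.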